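A few compounds are considered here, and "the series" means these few. Any claim that something is new, unique, unknown or untested is made for them only; others in the source may bear on it.

Series notes, Fatty-acid amide hydrolase 1 inhibition.

Of the compounds shown here, three have numbers so far. Compound 1 `O=C(O)c1ccc(-c2cnc(C(=O)CCc3ccc(-c4ccccc4)cc3)o2)cn1` gives 44 nM in an assay for inhibition of Fatty-acid amide hydrolase 1 (Rattus norvegicus); on this read-out higher numbers stand for weaker inhibition and lower numbers for stronger inhibition. Compound 3 `COC(=O)c1ccc(-c2cnc(C(=O)CCc3ccc(COc4ccccc4)cc3)o2)nc1` gives 3.5 nM in this assay, and compound 2 `O=C(O)c1cccc(-c2cnc(C(O)CCc3ccc(-c4ccccc4)cc3)o2)n1` gives 1100 nM. Compound 1 thus stands second highest of the three: compound 3 sits well below it, beyond the usual scatter, and compound 2 sits well above it, also beyond the scatter. Within the data shown here, the pairs 1/3 and 1/2 differ in more than one place, so no single step is drawn between them; their numbers are simply noted as they stand.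

Compound 4 `O=C(CCc1ccc(-c2ccccc2)cc1)c1ncc(-c2cccnc2)o1` has not yet been measured. It differs from compound 1 in a single place:

hydrogen in place of carboxy on an aromatic carbon

Among the measured compounds shown here, no step between measured compounds isolates this change. The shared core, the ketone and the chain ending in the biphenyl group are kept; only the carboxy on the six-membered aromatic ring with one nitrogen is lost. For the measured compounds named here, compound 3, the only compound without a free carboxy, gives the lowest number of the three, so a downward step, beyond the scatter, is expected for compound 4: a 4.4-fold lower number from compound 1 to compound 4 (0.64 log units; beyond the scatter). Compound 4 is therefore estimated at 10 nM in this assay, within a range of 2 nM to 60 nM.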

Compound 4, inhibition constant: 1.1 nM
Beside the measured number, compound 4's estimate is 9.1-fold (0.96 log units) above it; measured number below the stated range.
By their numbers in this assay, from the lowest: compound 4; then compound 3; then compound 1; then compound 2.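

The change from carboxy to hydrogen gives the series its first step at a single place, and in this assay it reads as a 40-fold lower number from compound 1 to compound 4 (1.60 log units; beyond the scatter), a large step beyond the scatter. With the shared core, the ketone and the chain ending in the biphenyl group all kept, the carboxy on an aromatic carbon next to the ring nitrogen is not needed for a low number, and going from 6-carboxypyridin-3-yl to pyridin-3-yl alone moves the number down this far. Nothing at hand bears on the reason for the size of this step.

Still open, as far as these compounds go, is whether another group at this same place, such as a primary amide, an amine or a hydroxymethyl group, would give a number close to that of compound 4 or of compound 1, and so whether this step reflects the loss of the carboxy specifically or would follow any group there. From the compounds shown here alone, it is also open whether the same change gives a step of similar size on a compound with an alcohol in place of the ketone, or with a longer chain.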